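Benzothiazole thioacetamide series: cytotoxicity notes

The source may report more compounds than this note shows. Statements on the series, on what has been measured and on what is new or still open speak of the compounds shown alone.

Measured compounds:
- compound 1 `COc1ccc(CNC(=O)CSc2nc3ccc(NC(=O)c4ccc(Cl)cc4)cc3s2)cc1`, in a functional assay on MCF7 cells (Homo sapiens) for cytotoxicity, read by MTT assay, with a stated time of 48 h (a higher number here means a weaker inhibitor, a lower number a stronger inhibitor), compound 1 gives 19200 nM
- compound 2 `COc1ccc(CNC(=O)CSc2nc3ccc(NC(C)=O)cc3s2)cc1`, in this assay compound 2 gives 20500 nM
- compound 3 `CNC(=O)CSc1nc2ccc(NC(C)=O)cc2s1`, for which this assay returns only a limit, > 100000 nM; this is a limit of the assay, not a number the limit of > 100000 nM in this assay, at which 1 of the 3 values shown sits.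

Compound 2 and compound 3 share a core that differs in one place (hydrogen in place of 4-methoxyphenyl on a saturated chain carbon bound to an amide-type nitrogen), and this gives an at least 4.8-fold higher number from compound 2 to compound 3 (0.68 log units; beyond the scatter). Compound 4 `CNC(=O)CSc1nc2ccc(NC(=O)c3ccc(Cl)cc3)cc2s1` is not yet measured; it differs from compound 3 by 4-chlorophenyl in place of methyl on a carbonyl carbon. The same change was made from compound 2 to compound 1 (4-chlorophenyl in place of methyl on a carbonyl carbon), where it gave a 1.1-fold lower number from compound 2 to compound 1 (0.03 log units; within the scatter). Since that earlier step stayed within scatter, the step from compound 3 to compound 4 is expected to be small as well, a number no higher from compound 3 to compound 4 (the limit leaves the size open), resting on a 1.1-fold lower number from compound 2 to compound 1 (0.03 log units; within the scatter). Compound 4 is therefore estimated at 100000 nM in this assay, with a range from 45000 nM to 300000 nM, and a limit rather than a number is likely.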

Compound 4, half-maximal inhibitory concentration: 29400 nM
Beside the measured number, compound 4's estimate is 3.4-fold (0.53 log units) above it, outside the stated range (below it).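

In this assay, 4-chlorophenyl in place of methyl on a carbonyl carbon gives an at least 3.4-fold lower number from compound 3 to compound 4 (0.53 log units; beyond the scatter), so the size of this step does not carry from one core to the other: the same change on two cores in this assay, a 1.1-fold lower number (0.03 log units; within the scatter) from compound 2 to compound 1 and an at least 3.4-fold lower number (0.53 log units; beyond the scatter) from compound 3 to compound 4, at least 3.1-fold (0.50 log units) apart, beyond the scatter of two such steps. Hydrogen in place of 4-methoxyphenyl on a saturated chain carbon bound to an amide-type nitrogen gives a 1.5-fold higher number from compound 1 to compound 4 (0.19 log units; within the scatter), and this step also depends on the core: the same change on two cores in this assay, an at least 4.8-fold higher number (0.68 log units; beyond the scatter) from compound 2 to compound 3 and a 1.5-fold higher number (0.19 log units; within the scatter) from compound 1 to compound 4, at least 3.1-fold (0.50 log units) apart, beyond the scatter of two such steps. Among these compounds, only two cores are compared, which shows no general rule, and the value for compound 3 is a limit, so the true sizes of the steps and gaps remain unknown: the limit of > 100000 nM in this assay, at which 1 of the 4 values shown sits.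

Going by these compounds, whether an amine or a carboxylic acid in place of the 4-chlorophenyl would follow either step stays open. The same holds for a longer chain in place of the 4-methoxyphenyl.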